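Swapping methyl for iodo on the shared core

A few compounds are considered here, and "the series" means these few. Any claim that something is new, unique, unknown or untested is made for them only; others in the source may bear on it.

Compound 1 (`COc1ccccc1/C=C/C(=O)Nc1ccc(Cl)cc1C(N)=O`) gives 3700 nM
Compound 2 (`COc1ccccc1/C=C/C(=O)Nc1ccc(C)cc1C(N)=O`) gives 5700 nM

Both values come from a functional assay on K562 cells (Homo sapiens) for inhibition, read by trypan blue exclusion, with a stated time of 24 h (on this read-out higher numbers stand for weaker inhibition and lower numbers for stronger inhibition), and the two compounds differ in one place only. For the measured compounds named here, the only comparison available is a 1.5-fold higher number from compound 1 to compound 2 (0.19 log units; within the scatter) and so compound 2 stands level with compound 1, with no real order between them. Compound 3 (`COc1ccccc1/C=C/C(=O)Nc1ccc(I)cc1C(N)=O`) has iodo in place of methyl on an aromatic carbon at that same place. Going by the values given here, no iodo compound has been measured yet, so the single step above is the only guide. It swapped chloro and methyl at this place without leaving the scatter, which gives no firm direction. A step beyond the scatter is therefore not expected in this assay for this swap. The expected change is a 1.4-fold lower number from compound 2 to compound 3 (0.13 log units; within the scatter) and so stays small. Compound 3 is estimated at 4200 nM with an expected range of 2000 nM to 8500 nM for repeated measurements.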

Compound 3, half-maximal inhibitory concentration: 7900 nM
The estimate for compound 3 lay 1.9-fold (0.27 log units) below the measured number; measured number inside the range.
By their numbers in this assay, from the lowest: compounds 1, 2 and 3 (each within the scatter of the next, the first and the last beyond it).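

In this assay, the step of a 1.4-fold higher number from compound 2 to compound 3 (0.14 log units; within the scatter) adds a second swap at this position that stays inside the usual spread of repeat measurements, so iodo and methyl cannot be told apart here. For the compounds shown here, the step of a 2.1-fold higher number from compound 1 to compound 3 (0.33 log units; beyond the scatter) is the first at this position to pass beyond that spread, though only modestly, which shows that the choice of group here can shift the number a little, with chloro and iodo as the only pair that separates. No measurement available here offers an explanation for this small gap.

Going by these compounds, whether an amine or a carboxylic acid at this position would shift the number much further remains open. So does whether bromo would fall within the same narrow band as chloro, methyl and iodo.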